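Fluoro Placement on the Sulfonamide Aryl Ring

The compounds below may be only part of what the source reports. "The series", "measured", "known", "first", "only" and "open" are said of these compounds alone.

Three sulfonamides sharing one core were tested in a functional assay on RAW264.7 cells (Mus musculus) for inhibition; on this read-out higher numbers stand for weaker inhibition and lower numbers for stronger inhibition. Compound 3 `CCOC(=O)C1=CCCCC1S(=O)(=O)Nc1ccc(Cl)cc1` gives 400 nM. Compound 1 `CCOC(=O)C1=CCCCC1S(=O)(=O)Nc1ccc(Cl)cc1F` gives 160 nM; it differs from compound 3 by fluoro in place of hydrogen on an aromatic carbon, and the step is a 2.5-fold lower number from compound 3 to compound 1 (0.40 log units; beyond the scatter). Compound 2 `CCOC(=O)C1=CCCCC1S(=O)(=O)Nc1cccc(F)c1` gives 150 nM; its core differs from that of compound 3 by 3-fluorophenyl in place of 4-chlorophenyl on a sulfonamide nitrogen, and the step is a 2.7-fold higher number from compound 2 to compound 3 (0.43 log units; beyond the scatter). Compound 4 `CCOC(=O)C1=CCCCC1S(=O)(=O)Nc1cccc(F)c1F` is not yet measured. It differs from compound 2 by fluoro in place of hydrogen on an aromatic carbon, the same kind of change as from compound 3 to compound 1, though here the entering fluoro is ortho to a fluoro group, whereas in compound 1 it is meta to a chloro group. For compound 4 a step of similar size, a 2.0-fold lower number from compound 2 to compound 4 (0.30 log units; within the scatter), is expected in this assay, resting on a 2.5-fold lower number from compound 3 to compound 1 (0.40 log units; beyond the scatter). Compound 4 is therefore estimated at 75 nM, between 30 nM and 250 nM.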

Compound 4, half-maximal inhibitory concentration: 140 nM
Compound 4: the middle estimate sits 1.9-fold (0.27 log units) below what was measured; low and high end bracket the measured number.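

On the core of compound 2, fluoro in place of hydrogen on an aromatic carbon gives a 1.1-fold lower number from compound 2 to compound 4 (0.03 log units; within the scatter), so the two compounds cannot be told apart on this read-out. Set beside the earlier step, this one does not differ from it by more than two such steps scatter: the same change on two cores in this assay, a 2.5-fold lower number (0.40 log units; beyond the scatter) from compound 3 to compound 1 and a 1.1-fold lower number (0.03 log units; within the scatter) from compound 2 to compound 4, 2.3-fold (0.37 log units) apart, within the scatter of two such steps. Among these compounds, this shows no measurable difference in how the change carries between the two cores, but it does not show that the step has the same size on both, since one of the two steps lies within the scatter and only two cores are compared.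

The compounds shown leave open whether the step holds on further cores. They also leave open what happens when a methoxy group or an amine enters in place of fluoro, or when a carboxylic acid replaces the ethyl ester.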